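Pyrazolopyrimidinone thioethers: phenyl replacing hydroxyphenyl

This account rests on a few compounds, and the source may have more. Where it says the series, first, only, none or still open, it means among the compounds named here.

Measured compounds:
compound 1 `CC(Sc1nc2c(cnn2C)c(=O)n1-c1ccccc1)c1ccncc1` – 451 nM
compound 2 `CC(Sc1nc2c(cnn2C)c(=O)n1-c1ccccc1)c1cccc(O)c1` – 130 nM

Both compounds share the core and differ only in the aryl group on the saturated chain carbon next to sulfur. In an assay on isolated protein for inhibition of aldehyde dehydrogenase 1A1 (Homo sapiens) (a lower number here means a stronger inhibitor, a higher number a weaker inhibitor), compound 1 gives 451 nM, and compound 2 gives 130 nM. For the measured compounds named here, the single step on hand, a 3.5-fold lower number from compound 1 to compound 2 (0.54 log units; beyond the scatter), comes from putting 3-hydroxyphenyl in place of pyridin-4-yl. Compound 2 therefore stands with the lowest number of the two, and the gap to compound 1 is beyond the scatter.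

Compound 3 `C[C@H](Sc1nc2c(cnn2C)c(=O)n1-c1ccccc1)c1ccccc1` is the next member. Its change from compound 2 is a group of 8 heavy atoms (8 carbon; one six-membered aromatic ring of carbon only) in place of a group of 9 heavy atoms (8 carbon, 1 oxygen; one six-membered aromatic ring of carbon only), on a sulfur, so the hydroxyl bearing ring gives way to 1-phenylethyl, now as one defined stereocentre. Going by the values given here, no measured pair shows a phenyl against a 3-hydroxyphenyl; the only comparison is the aryl swap in a 3.5-fold lower number from compound 1 to compound 2 (0.54 log units; beyond the scatter), which shows that this position responds to the ring chosen. Losing the hydroxyl is expected to cost somewhat, and compound 3 is estimated at 250 nM (range 90 nM to 700 nM), a step of a 1.9-fold higher number from compound 2 to compound 3 (0.28 log units; within the scatter) that may or may not clear the scatter.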

Compound 3, half-maximal inhibitory concentration: 1410 nM
For compound 3 the middle estimate is 5.6-fold (0.75 log units) below the measured one; the whole stated range lies below it.
By their numbers in this assay, from the lowest: compound 2; then compound 1; then compound 3.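

Working notes on the sulfur substituent: in this assay, 1-phenylethyl gives the highest number of the three compounds, with the step from the hydroxyl-bearing group being large (an 11-fold higher number from compound 2 to compound 3 (1.04 log units; beyond the scatter)) and the step from 1-(pyridin-4-yl)ethyl modest (a 3.1-fold higher number from compound 1 to compound 3 (0.50 log units; beyond the scatter)). The position therefore responds not only to a swap between the two earlier rings: both of those rings give lower numbers than the plain phenyl ring of compound 3, and the group carrying the hydroxyl gives the lowest. No measurement on hand explains why this change costs so much.

The step to compound 3 combines loss of the hydroxyl with one defined stereocentre, which compounds 1 and 2 do not show, so the contribution of each remains unseparated, and the opposite stereocentre in compound 3 remains an open comparison. Also open, going by these compounds, is whether the hydroxyl itself is needed, a question that an amine or a carboxylic acid on the phenyl ring in its place would address, together with a matched pair that keeps the stereocentre the same.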